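The source may hold more compounds than are shown below. What is called first, only, known or untested is meant among the compounds shown, and "the series" means these compounds.

Working notes on the series. Compound 1 `O=C(O)c1csc(-n2nc(-c3ccccc3)c3ccc(O)cc32)n1` gives 140 nM in an assay on isolated protein for antagonist activity at prostaglandin E2 receptor EP1 subtype (Homo sapiens), read by reporter gene assay; on this read-out higher numbers stand for weaker inhibition and lower numbers for stronger inhibition; compound 2 `O=C(O)c1csc(-n2nc(-c3ccc(Cl)cc3)c3ccccc32)n1` gives 12 nM in this assay, the lower of the two numbers, with compound 1 standing apart beyond the scatter. Compound 3 `O=C(O)c1csc(-n2nc(N3CCCCC3)c3ccccc32)n1` has not yet been run. Its change from compound 2 is piperidin-1-yl in place of 4-chlorophenyl on an aromatic carbon. Among the compounds with values here, no measured pair shows this kind of change, so the expectation rests on compound 2 alone. A weakening step is expected, a 10-fold higher number from compound 2 to compound 3 (1.00 log units; beyond the scatter), since nothing in the series supports that a non-aromatic ring holds the level of compound 2. Compound 3 is estimated at 120 nM, within 25 nM to 700 nM.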

Compound 3, half-maximal inhibitory concentration: 16 nM
Compound 3: middle estimate off by 7.5-fold (0.88 log units), on the high side, outside the stated range (below it).
By their numbers in this assay, from the lowest: compounds 2 and 3 (each within the scatter of the next); then compound 1.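

In this assay, piperidin-1-yl in place of 4-chlorophenyl on this aromatic carbon gives a 1.3-fold higher number from compound 2 to compound 3 (0.12 log units; within the scatter), so the two compounds cannot be told apart. At this position, an aromatic ring is therefore not required for a number at this level: a six-membered non-aromatic ring with 1 hetero atom serves as well as a six-membered aromatic ring of carbon only. No available data explain this match. Still open, from the compounds shown here alone, is whether morpholin-4-yl, pyrrolidin-1-yl or an open-chain amine such as diethylamino at this position would stay at the same level.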